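Aryl substituent variation on the chain carbon of the shared core

This account rests on a few compounds, and the source may have more. Where it says the series, first, only, none or still open, it means among the compounds named here.

In a functional assay on the whole organism (strain Lewis) with Rattus norvegicus as the target, with a stated time of 24 h, at a dose of 2 mg/kg by the oral route (on this read-out lower numbers stand for less inhibition and higher numbers for more inhibition at the one dose given (going by the name of the read-out)), compound 2 `COc1ccccc1SC[C@@H]1CCc2cc([C@H]3CC[C@](N)(CO)C3)ccc2C1` gives 78%, the higher of the two numbers in hand, though its nearest neighbour compound 1 `N[C@]1(CO)CC[C@H](c2ccc3c(c2)CC[C@@H](COc2ccc(F)cc2)C3)C1`, which gives 74%, lies within the scatter of it: a number 4 percentage points higher from compound 1 to compound 2 (within the scatter). Compound 3 `COc1cccc(OC[C@@H]2CCc3cc([C@H]4CC[C@](N)(CO)C4)ccc3C2)c1` differs from compound 2 by 3-methoxyphenoxy in place of (2-methoxyphenyl)sulfanyl on a saturated chain carbon bound to a saturated ring carbon. Within the data shown here, only one measured step bears on this change, the exchange of 4-fluorophenoxy for (2-methoxyphenyl)sulfanyl at the same saturated chain carbon from compound 1 to compound 2, and that step stayed within the scatter. Nothing in hand separates the oxygen-linked from the sulfur-linked group, nor the position of the methoxy group, so no step beyond the scatter is expected; the expected step is a number 4 percentage points lower from compound 2 to compound 3 (within the scatter). On that basis compound 3 is estimated at 74% in this assay, with a range from 58% to 88%.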

Compound 3, a percentage reported as inhibition, in the whole organism at one dose (the size of the read-out at that dose, not a potency): 86%
Estimate against measurement, compound 3: 12 percentage points below; the measured number falls inside the stated range.
By their numbers in this assay, from the lowest: compounds 1, 2 and 3 (each within the scatter of the next, the first and the last beyond it).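

In this assay, among these compounds, the change of 4-fluorophenyl to 3-methoxyphenyl on an oxygen on a saturated carbon gives a number 12 percentage points higher from compound 1 to compound 3 (beyond the scatter) and is the first step to pass the scatter. The exchange of (2-methoxyphenyl)sulfanyl for 3-methoxyphenoxy on the saturated chain carbon gives a number 8 percentage points higher from compound 2 to compound 3 (within the scatter) so this pair does not separate the sulfur-linked group from the oxygen-linked one at this dose. No measurement in hand gives a reason for either step.

Going by these compounds, whether the higher number of compound 3 goes with the methoxy group or with the absence of fluorine stays open, as the two groups differ in both the substituent and its place on the ring. Also open, on these data alone, is how an amine, a carboxylic acid or a longer chain in place of 3-methoxyphenoxy on this saturated chain carbon would read out.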